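Shared core series: amino in place of hydroxy

This account rests on a few compounds, and the source may have more. Where it says the series, first, only, none or still open, it means among the compounds named here.

Three compounds on the shared core have numbers in a functional assay on HCT-15 cells (Homo sapiens) for cytotoxicity, read by CCK-8 assay and cell counting, with a stated time of 72 h; a lower number here means a stronger inhibitor, a higher number a weaker inhibitor. Compound 1 `COc1ccc(-c2cc3ccccc3c(-c3cccc(OC)c3)n2)cc1` gives 1300 nM. Compound 2 `COc1cc(OC)cc(-c2cc3ccccc3c(-c3ccc(O)cc3)n2)c1` gives 2780 nM. Compound 3 `COc1ccc(-c2cc3cc(C)ccc3c(-c3cccc(O)c3)n2)c(C)c1` gives 1750 nM. On the bare numbers compound 3 has the second highest of the three, with compound 1 its nearest neighbour and compound 2 its furthest, yet both gaps fall within the scatter of repeated measurements, so the three compounds cannot be told apart on this evidence.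

Compound 4 `COc1ccc(-c2cc3cc(C)ccc3c(-c3cccc(N)c3)n2)c(C)c1` has not been measured. It differs from compound 3 in one place: amino in place of hydroxy on an aromatic carbon. Going by the values given here, no pair of measured compounds shows this exchange, so its effect in this assay cannot be read from the series. What is counted leaves and enters unchanged in donor and acceptor number, and the rest of the molecule is kept.

On that basis no step beyond the scatter is expected from compound 3 to compound 4 in this assay, no change at the digits printed from compound 3 to compound 4 (within the scatter). Compound 4 is therefore estimated at 1750 nM, with a range from 700 nM to 4500 nM.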

Compound 4, half-maximal inhibitory concentration: 2770 nM
Estimate against measurement, compound 4: 1.6-fold (0.20 log units) below; measured number inside the range.
By their numbers in this assay, from the lowest: compounds 1, 3, 4 and 2 (each within the scatter of the next, the first and the last beyond it).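

In this assay, going by these compounds alone, the change from 3-hydroxyphenyl to 3-aminophenyl gives a 1.6-fold higher number from compound 3 to compound 4 (0.20 log units; within the scatter) and is the first exchange that can be read at a single place. The earlier compounds shown here differ from one another in several places at once, so they could not speak to any one group, whereas this pair keeps the rest of the molecule and shows that hydroxy and amino at this place cannot be told apart in this assay. Nothing available beyond these cell numbers bears on the result, and no explanation for it can be offered.

Still open, from the compounds shown here alone, is how a carboxylic acid, an acetamido group or a fluoro at this place would read, and so whether the position responds to any exchange at all. Also open, going by these compounds, is whether amino in place of hydroxy reads the same on the other compounds, as the exchange rests on this one pair and the substituents elsewhere on the shared core stay fixed within it.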